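Replacing the Ring-Nitrogen Benzyl with a Carbamoyl Group

This account rests on a few compounds, and the source may have more. Where it says the series, first, only, none or still open, it means among the compounds named here.

Compound 1 `NC(=O)c1c(NC(=O)c2ccc(C(F)(F)F)cc2)sc2c1CCN(Cc1c(Cl)cccc1Cl)C2` gives 10600 nM in a functional assay on HL-60 cells (Homo sapiens) for antiproliferative activity, with a stated time of 24 h; on this read-out higher numbers stand for weaker inhibition and lower numbers for stronger inhibition.
Compound 2 `NC(=O)c1c(NC(=O)c2cccc([N+](=O)[O-])c2)sc2c1CCN(Cc1c(Cl)cccc1Cl)C2` gives 18400 nM in this assay.

Compound 2 and compound 1 lie within the scatter of each other, since a 1.7-fold higher number from compound 1 to compound 2 (0.24 log units; within the scatter). Compound 3 `NC(=O)c1c(NC(=O)c2cccc([N+](=O)[O-])c2)sc2c1CCN(C(=O)Nc1ccccc1Cl)C2` differs from compound 2 by (2-chlorophenyl)carbamoyl in place of 2,6-dichlorobenzyl on an amine nitrogen in a ring. The only measured step concerns the group on the carbonyl carbon and does not touch the ring nitrogen, so no shown step bears on this change, and the expected size of a 1.2-fold lower number from compound 2 to compound 3 (0.09 log units; within the scatter) in this assay carries no direction and wide uncertainty. Compound 3 is therefore estimated at 15000 nM, within 3000 nM to 60000 nM.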

Compound 3, half-maximal inhibitory concentration: 18500 nM
The estimate for compound 3 lay 1.2-fold (0.09 log units) below the measured number; measured number inside the range.
By their numbers in this assay, from the lowest: compounds 1, 2 and 3 (each within the scatter of the next).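

For the compounds shown here, compound 3 shows that the amine nitrogen in a ring can carry (2-chlorophenyl)carbamoyl in place of 2,6-dichlorobenzyl with no readable difference in this assay, where the change gives a 1.0-fold higher number from compound 2 to compound 3 (0.00 log units; within the scatter) and stays in the micromolar range of the earlier compounds. Going by these compounds alone, this is the first reading at this position, since the earlier step concerned only the group on the carbonyl carbon. Nothing available explains this result. The compounds shown leave open how a free ring amine, an acetyl group or a longer alkyl chain on this nitrogen would read, and whether the same swap gives the same result with 4-(trifluoromethyl)phenyl on the carbonyl carbon.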